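Phenyl to Pyridin-3-yl on a Carbamate Oxygen

A few compounds are considered here, and "the series" means these few. Any claim that something is new, unique, unknown or untested is made for them only; others in the source may bear on it.

Measured in an ADME assay on S9 fraction from liver (Rattus norvegicus) for metabolic stability, read by HPLC, using NADPH, with a stated time of 30 min; on this read-out lower numbers stand for a less stable compound and higher numbers for a more stable compound:
- compound 1, `O=C(NCCCCCCn1ccc2ccccc21)Oc1cccnc1`: 47%
- compound 2, `O=C(NCCCCCn1ccc2ccccc21)Oc1ccccc1`: 52%
- compound 3, `O=C(NCCCCCCn1ccc2ccccc21)Oc1ccccc1`: 50%

Three carbamates have been measured, and a fourth, compound 4 with the structure `O=C(NCCCCCn1ccc2ccccc21)Oc1cccnc1`, has not. Compound 2 and compound 3 carry different cores; the difference between the two cores is not broken down here, and in this assay their values lie within the scatter of one another.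

The change from compound 3 to compound 1 is pyridin-3-yl in place of phenyl on an oxygen next to a carbonyl group, and it gave a number 3 percentage points lower from compound 3 to compound 1 (within the scatter). The change from compound 2 to compound 4 is pyridin-3-yl in place of phenyl on an oxygen next to a carbonyl group, the same change at the same place, made this time on the core of compound 2.

Among the measured compounds shown here, because the only measured instance of this change gave a number 3 percentage points lower from compound 3 to compound 1 (within the scatter), a step of similar size is expected for compound 4, namely a number 3 percentage points lower from compound 2 to compound 4 (within the scatter) from compound 2. That rests on a single pair, so the range is kept broad. In this assay compound 4 is estimated at 49%, expected to fall between 36% and 62%.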

Compound 4, percent of the compound remaining: 43%
Beside the measured number, compound 4's estimate is 6 percentage points above it; the range from low to high includes it.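

In this assay, pyridin-3-yl in place of phenyl on an oxygen next to a carbonyl group gave a number 9 percentage points lower from compound 2 to compound 4 (within the scatter), and the two available steps cannot be told apart: the same change on two cores in this assay, a number 3 percentage points lower (within the scatter) from compound 3 to compound 1 and a number 9 percentage points lower (within the scatter) from compound 2 to compound 4, 6 percentage points apart, within the scatter of two such steps. As far as these two pairs go, the change carries from the core of compound 3 to the core of compound 2 without any detectable difference between the cores in how it reads out. This does not establish that the change has a real effect on stability on either core, since each step lies within the scatter, and two pairs say nothing about how it would behave on any other core.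

The compounds shown leave open how a core with a longer chain would respond to the same change. They also leave open how this read-out would respond to a different group on that oxygen, such as a pyrimidinyl or cyclohexyl group.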